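This account rests on a few compounds, and the source may have more. Where it says the series, first, only, none or still open, it means among the compounds named here.

Measured in a functional assay on PC-12 cells (Rattus norvegicus) for cytotoxicity, read by MTT assay, with stated times of 2 h and 24 h, tested at 10 uM; a higher number here means a stronger effect of the compound at the concentration tested, a lower number a weaker effect:
- compound 1, `Cc1ccc(-n2nc(-c3ccc(C(F)(F)F)cc3O)nc2-c2ccccc2O)cc1`: 102%
- compound 2, `CC(C)c1ccc(-n2nc(-c3ccc(C(F)(F)F)cc3O)nc2-c2ccccc2O)cc1`: 108%
- compound 3, `Oc1cc(C(F)(F)F)ccc1-c1nc(-c2ccccc2O)n(-c2ccc(Cl)cc2)n1`: 96.1%

Compound 2 gives the highest of the three numbers. Within the data shown here, its nearest neighbour is compound 1, with the step of a number 6 percentage points higher from compound 1 to compound 2 (within the scatter), so the two are not separable; its furthest is compound 3, with the step of a number 11.9 percentage points lower from compound 2 to compound 3 (beyond the scatter), the only step among the measured compounds that stands out.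

The compound still to be measured is compound 4, `Oc1cc(C(F)(F)F)ccc1-c1nc(-c2ccccc2O)n(-c2ccc(I)cc2)n1`. It differs from compound 2 at one place: iodo in place of isopropyl on an aromatic carbon.

Among the measured compounds shown here, two measured steps bear on this change. Exchanging isopropyl for chloro on the same aromatic carbon gave a number 11.9 percentage points lower from compound 2 to compound 3 (beyond the scatter), a modest fall, while exchanging methyl for chloro gave a number 5.9 percentage points lower from compound 1 to compound 3 (within the scatter), a fall that does not rise above the scatter. Iodo, like chloro, replaces the isopropyl with a single heavy atom, so a modest fall of about the size seen from compound 2 to compound 3 is expected, though it may well remain within the scatter.

For compound 4 the estimate in this assay is therefore 96%, with a range from 84% to 108%, which is expected to mean a step of a number 12 percentage points lower from compound 2 to compound 4 (beyond the scatter).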

Compound 4, a percentage reported as activity, at one concentration (the size of the read-out at that concentration, not a potency): 105%
Estimate against measurement, compound 4: 9 percentage points below, and the stated range covers the measured number.
By their numbers in this assay, from the lowest: compounds 3, 1, 4 and 2 (each within the scatter of the next, the first and the last beyond it).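

In this assay, iodo in place of isopropyl on this aromatic carbon, para to a large group, gives a number 3 percentage points lower from compound 2 to compound 4 (within the scatter) and so does not separate the two compounds, although chloro in the same exchange had stood apart. Iodo is also not separable from the other two groups, with a number 8.9 percentage points higher from compound 3 to compound 4 (within the scatter) and a number 3 percentage points higher from compound 1 to compound 4 (within the scatter), which leaves compounds 2 and 3 as the only pair set apart and shows that a single heavy atom in place of isopropyl does not by itself produce that separation. No evidence is at hand on what lies behind these numbers.

Open, from the compounds shown here alone, is whether an amine, a carboxylic acid or a longer alkyl chain at this place would leave the number where these four groups put it. The compounds shown also leave open whether changes elsewhere on the shared core would matter more.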